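Phenyl to Butyl on the Alkyne Arm of Compound 2

A few compounds are considered here, and "the series" means these few. Any claim that something is new, unique, unknown or untested is made for them only; others in the source may bear on it.

Measured compounds:
compound 1 `O=c1[nH]c(=O)n(CCC(CO)CO)cc1-c1cccs1` with 7800 nM
compound 2 `O=c1[nH]c(=O)n(CCC(CO)CO)cc1C#CCc1ccccc1` with 63800 nM

In a functional assay on HeLa cells (Homo sapiens) for antiproliferative activity, read by MTT assay, with a stated time of 72 h (a lower number here means a stronger inhibitor, a higher number a weaker inhibitor), compound 1 gives 7800 nM, while compound 2 gives 63800 nM. Among the measured compounds shown here, compound 2 therefore stands at the highest number of the two, and its only neighbour, compound 1, lies at a lower number, a gap beyond the scatter. The two compounds differ in more than one place, so their gap is reported only as what the two values show.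

Compound 3 `CCCCCC#Cc1cn(CCC(CO)CO)c(=O)[nH]c1=O` is not yet measured in this assay. It is reached from compound 2 by one change: butyl in place of phenyl on a saturated chain carbon bound to a triple-bonded carbon. For the measured compounds named here, no measured pair in this set carries the same change, so nothing here tells how much a swap of phenyl for butyl at that chain carbon matters. The shared core and the alkyne link stay as in compound 2. The step from compound 2 to compound 3 is expected to be small, a 1.3-fold lower number from compound 2 to compound 3 (0.11 log units; within the scatter), not clearly beyond the scatter in either direction. Compound 3 is accordingly estimated at 50000 nM, with a range from 15000 nM to 160000 nM.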

Compound 3, half-maximal inhibitory concentration: 76300 nM
Compound 3: the middle estimate sits 1.5-fold (0.18 log units) below what was measured, within the range that was stated.
By their numbers in this assay, from the lowest: compound 1; then compounds 2 and 3 (each within the scatter of the next).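

In this assay the swap of butyl for phenyl on a saturated chain carbon bound to a triple-bonded carbon gives a small step (a 1.2-fold higher number from compound 2 to compound 3 (0.08 log units; within the scatter)), so in this pair a six-membered aromatic ring of carbon and a ringless chain of butyl cannot be told apart at this place. Among the compounds shown here, the larger difference lies elsewhere: hept-1-yn-1-yl in place of thiophen-2-yl on an aromatic carbon gives the first step beyond the scatter that can be read at a single place (a 9.8-fold higher number from compound 1 to compound 3 (0.99 log units; beyond the scatter)), and this marks the whole group on the aromatic carbon, rather than the end of the alkyne arm, as the change that shows up in this set. Nothing in the data shown accounts for the size of either step.

On these data alone, whether the chain carbon stays this indifferent with an amine, a carboxylic acid or a chain longer than butyl in the same place remains open. So does whether the lower number of compound 1 belongs to thiophen-2-yl itself or would also appear with phenyl or furan-2-yl on that aromatic carbon.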